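The source may hold more compounds than are shown below. What is called first, only, known or untested is meant among the compounds shown, and "the series" means these compounds.

Series notes. Compound 1, `NC1=NC2(CCOCC2)N(OCCCOc2ccccc2)C(N)=N1`, is the reference point. Among the measured compounds shown here, in a functional assay on A549 cells (Homo sapiens) for antiproliferative activity, read by MTT assay, with a stated time of 72 h (a lower number here means a stronger inhibitor, a higher number a weaker inhibitor), compound 1 gives 1080 nM, the higher of the two numbers measured so far. Compound 2, `NC1=NC2(CCSCC2)N(OCCCOc2ccccc2Cl)C(N)=N1`, differs from compound 1 in more than one place; in this assay compound 2 gives 80 nM, and the gap between the two values lies beyond the scatter, though with two changes at once it cannot be assigned to either of them.

The next compound, compound 3, `NC1=NC2(CCOCC2)N(OCCCOc2cccc(Cl)c2)C(N)=N1`, changes compound 1 in one place only: chloro in place of hydrogen on an aromatic carbon, meta to a large group, which one bond further out reads phenoxy to 3-chlorophenoxy. For the measured compounds named here, no step between measured compounds isolates this change. Compound 2 carries a chloro as well, on a different aromatic carbon and together with a second change, so its 80 nM is only a loose pointer. The expectation for compound 3 is a modest step toward a lower number, a 2.7-fold lower number from compound 1 to compound 3 (0.43 log units; beyond the scatter), beyond the scatter but short of the gap seen to compound 2. Compound 3 is therefore estimated at 400 nM, with a range of 150 nM to 1200 nM.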

Compound 3, half-maximal inhibitory concentration: 150 nM
The estimate for compound 3 lay 2.7-fold (0.43 log units) above the measured number; the range from low to high includes it.
By their numbers in this assay, from the lowest: compounds 2 and 3 (each within the scatter of the next); then compound 1.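

In this assay, among the compounds shown here, the change from phenoxy to 3-chlorophenoxy gives a 7.2-fold lower number from compound 1 to compound 3 (0.86 log units; beyond the scatter) on the otherwise unchanged core of compound 1, the first reading that isolates a single change. Chloro in place of hydrogen on an aromatic carbon, meta to a large group, is thus enough on its own to move the number beyond the scatter, something the gap to compound 2 could not show with two changes at once. Nothing shown explains why this chloro has this effect, so the step stands as an observation only.

On these data alone, it remains open whether chloro on the different aromatic carbon seen in compound 2 would give a step of similar size on the core of compound 1, since compound 2 carries a second change and cannot settle this. Also open, as far as these compounds go, is whether the step is specific to chloro or would also appear with fluoro, methoxy, trifluoromethyl or an amine in the same place, and whether it would survive a longer chain leading to the 3-chlorophenoxy group.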